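Series notes: nitro in place of chloro, compound 2 to 3

A few compounds are considered here, and "the series" means these few. Any claim that something is new, unique, unknown or untested is made for them only; others in the source may bear on it.

Compound 1 `O=c1ccoc2cc(OCc3cn(Cc4ccc(Cl)cc4Cl)nn3)ccc12` carries a 2,4-dichlorophenyl group. In a functional assay on MDA-MB-231 cells (Homo sapiens) for cytotoxicity, read by MTT assay, with a stated time of 48 h (on this read-out lower numbers stand for stronger inhibition and higher numbers for weaker inhibition), compound 1 reaches only the assay limit, > 100000 nM. Compound 2 `O=c1ccoc2cc(OCc3cn(Cc4cccc(Cl)c4)nn3)ccc12` carries 3-chlorophenyl instead. In this assay compound 2 likewise gives only a limit, > 100000 nM. The step that the two limits leave unreadable from compound 1 to compound 2 therefore cannot be sized. Compound 2 thus stands at the limit of the range shown. Both values shown sit there (the limit of > 100000 nM in this assay, at which 2 of the 2 values shown sit).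

Compound 3 `O=c1ccoc2cc(OCc3cn(Cc4cccc([N+](=O)[O-])c4)nn3)ccc12` differs from compound 2 by nitro in place of chloro on an aromatic carbon. Going by the values given here, no measured step touches this change directly; the only step known, from a dichlorinated to a monochlorinated aryl, is unreadable, and both of its members sit at the limit (the limit of > 100000 nM in this assay, at which 2 of the 2 values shown sit). Nothing in the series shows a measured potency, so there is no basis for expecting a readable value. The expected step is a number no higher from compound 2 to compound 3 (the limit leaves the size open), no shift beyond the scatter. Compound 3 is expected to give about 100000 nM in this assay, within 50000 nM to 200000 nM, with a further limit the most likely outcome.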

Compound 3, half-maximal inhibitory concentration: > 100000 nM
Compound 3: only a limit was reported; the forecaster's own chance of this, stated with the estimate: 80%; the middle value lies on the limit itself.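

In this assay compound 3 gives > 100000 nM, a limit and not a number. No step among compound 1, compound 2 and compound 3 can be read: the limit of > 100000 nM in this assay, at which 3 of the 3 values shown sit.

The compounds shown leave open how the 2,4-dichlorophenyl, 3-chlorophenyl and 3-nitrophenyl groups rank against one another in this assay, and whether any change on the shared core gives a readable value.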